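A few compounds are considered here, and "the series" means these few. Any claim that something is new, unique, unknown or untested is made for them only; others in the source may bear on it.

Compound 1 `COc1cc(-c2cc(/C=C/C(=O)c3ccc(Cl)c(Cl)c3)[nH]n2)cc(OC)c1OC`: 95%
Compound 2 `COc1ccc(C(=O)/C=C/c2cc(-c3cc(OC)c(OC)c(OC)c3)n[nH]2)cc1`: 91%

Among the compounds with values here, in a functional assay on Malme-3M cells (Homo sapiens) for cytotoxicity, read by sulforhodamine B assay, with a stated time of 48 h, tested at 0.1 uM (a higher number here means a weaker effect of the compound at the concentration tested, a lower number a stronger effect), compound 2 gives 91%, the lower of the two numbers seen, yet its only neighbour, compound 1, sits a step away that the data call within the scatter, a number 4 percentage points lower from compound 1 to compound 2 (within the scatter). Compound 3 `COc1cc(-c2cc(/C=C/C(=O)c3ccc(F)c(F)c3)[nH]n2)cc(OC)c1OC` is the same core with 3,4-difluorophenyl in place of 4-methoxyphenyl on a carbonyl carbon. Within the data shown here, the one measured step that bears on an exchange at the carbonyl carbon, a number 4 percentage points lower from compound 1 to compound 2 (within the scatter), changed nothing beyond the scatter, so for compound 3 no step beyond the scatter is expected, a number 2 percentage points higher from compound 2 to compound 3 (within the scatter). Compound 3 is therefore estimated at 93%, within 80% to 105%.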

Compound 3, a percentage reported as activity, at one concentration (the size of the read-out at that concentration, not a potency): 90%
The estimate for compound 3 lay 3 percentage points above the measured number, and the stated range covers the measured number.
By their numbers in this assay, from the lowest: compounds 3, 2 and 1 (each within the scatter of the next).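

In this assay, the 3,4-difluorophenyl group gives a number 1 percentage points lower from compound 2 to compound 3 (within the scatter) and a number 5 percentage points lower from compound 1 to compound 3 (within the scatter), so neither step lies beyond the scatter. With three different aromatic groups now on the carbonyl carbon, this single concentration still cannot tell them apart, and this holds for the two halogen-bearing rings as well as for the 4-methoxyphenyl ring. No supporting measurement explains why these groups read alike. Still open, going by these compounds, is whether a group of another kind at this place, such as an amine, a carboxylic acid or a longer chain, would give a step beyond the scatter.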